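This account rests on a few compounds, and the source may have more. Where it says the series, first, only, none or still open, it means among the compounds named here.

Compounds measured so far:

compound 1, `CCCCn1c(SCc2cc([N+](=O)[O-])ccc2OC)nc2cc(NC(=O)NC(C)(C)C)ccc21`, with 23 nM in an assay on isolated protein for inhibition of Gonadotropin-releasing hormone receptor (Homo sapiens); a lower number here means a stronger inhibitor, a higher number a weaker inhibitor
compound 2, `COc1ccc([N+](=O)[O-])cc1CSc1nc2cc(NC(=O)NC(C)(C)C)ccc2n1Cc1ccccc1`, with 28 nM in this assay

Compound 2 holds the higher of the two numbers, though its gap to compound 1 is small: the step of a 1.2-fold higher number from compound 1 to compound 2 (0.09 log units; within the scatter) lies within the scatter, so the two are not distinguishable on these data. That step exchanged phenyl for propyl on the saturated chain carbon bound to the aromatic nitrogen, and the read-out barely moved.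

Compound 3, `COc1ccc([N+](=O)[O-])cc1CSc1nc2cc(NC(=O)NC(C)(C)C)ccc2n1Cc1ccccn1`, is not yet measured. It differs from compound 2 by pyridin-2-yl in place of phenyl on a saturated chain carbon bound to an aromatic nitrogen, or, cut one bond further out, benzyl to (pyridin-2-yl)methyl. Among the compounds with values here, only the step from compound 1 to compound 2 bears on this position, and it shows the assay tolerating a large change there with no shift beyond the scatter. Within the data shown here, no measured pair tells what a ring nitrogen does at this place, so the estimate leans on that one step alone.

Compound 3 is therefore expected to land near compound 2, with a step of a 1.3-fold higher number from compound 2 to compound 3 (0.10 log units; within the scatter), and its value is estimated at 35 nM, within 12 nM to 100 nM.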

Compound 3, half-maximal inhibitory concentration: 43 nM
The estimate for compound 3 lay 1.2-fold (0.09 log units) below the measured number; the measured number falls inside the stated range.
By their numbers in this assay, from the lowest: compounds 1, 2 and 3 (each within the scatter of the next).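

Pyridin-2-yl is the first group at this place to carry a ring nitrogen and a hydrogen-bond acceptor, where phenyl has neither, and in this assay that exchange gives a 1.5-fold higher number from compound 2 to compound 3 (0.19 log units; within the scatter). Set against the propyl group, pyridin-2-yl gives a 1.9-fold higher number from compound 1 to compound 3 (0.27 log units; within the scatter), so propyl, phenyl and pyridin-2-yl on this saturated chain carbon cannot be told apart on these data, and a hetero atom in the ring has joined the large change already seen here without a shift beyond the scatter. No measured evidence bears on what lies behind these small differences.

The compounds shown leave open whether a group of a different kind at this place, such as a carboxylic acid, a primary amine or a longer chain ending in morpholine, would move the number beyond the scatter. They also leave open whether pyridin-3-yl or pyridin-4-yl would read the same as pyridin-2-yl, and whether this tolerance would hold if the nitro or methoxy groups elsewhere in the shared core were exchanged.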